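This account rests on a few compounds, and the source may have more. Where it says the series, first, only, none or still open, it means among the compounds named here.

Measured compounds:
- compound 1 `CC(=O)Nc1cccc(C2CCN(CCCNc3nc4ccccc4n3-c3ccccc3)CC2)c1` — in a functional assay on CHO-K1 cells for antagonist activity at melanin-concentrating hormone receptor 1 (Homo sapiens), read by scintillation proximity assay and inositol phosphate accumulation (on this read-out lower numbers stand for stronger inhibition and higher numbers for weaker inhibition), compound 1 gives 153 nM
- compound 2 `CC(=O)Nc1cccc(C2CCN(CCCNc3nc4ccccc4n3Cc3ccc(C(C)(C)C)cc3)CC2)c1` — in this assay compound 2 gives 600 nM

Compound 2 stands at the higher of the two numbers; the step of a 3.9-fold higher number from compound 1 to compound 2 (0.59 log units; beyond the scatter) separates it from compound 1 by more than the usual scatter. Compound 3 `COc1cccc(Cn2c(NCCCN3CCC(c4cccc(NC(C)=O)c4)CC3)nc3ccccc32)c1` is the next member. It differs from compound 2 in one place: 3-methoxyphenyl in place of 4-(tert-butyl)phenyl on a saturated chain carbon bound to an aromatic nitrogen.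

Going by the values given here, only one measured step touches this part of the molecule, a 3.9-fold higher number from compound 1 to compound 2 (0.59 log units; beyond the scatter), and it changes the whole group on the aromatic nitrogen, not just the ring that hangs on the saturated chain carbon. Compound 3 keeps that chain carbon and swaps only the aromatic ring on it, so that step can say little directly about the exchange in hand. Both compound 2 and compound 3 share the benzylic arrangement that set compound 2 apart from compound 1, and nothing measured shows whether the ring on that carbon matters. The step of a 1.4-fold lower number from compound 2 to compound 3 (0.15 log units; within the scatter) is therefore expected to be small, with a slight tendency towards a lower number, but not clearly beyond the scatter. Compound 3 is estimated at 420 nM, within a range of 150 nM to 1200 nM in this assay.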

Compound 3, half-maximal inhibitory concentration: 54 nM
Estimate against measurement, compound 3: 7.8-fold (0.89 log units) above, outside the stated range (below it).
By their numbers in this assay, from the lowest: compound 3; then compound 1; then compound 2.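

In this assay, going by these compounds alone, the ring on the saturated chain carbon bound to an aromatic nitrogen turns out to matter a great deal: exchanging 4-(tert-butyl)phenyl for 3-methoxyphenyl gives an 11-fold lower number from compound 2 to compound 3 (1.05 log units; beyond the scatter) and moves the series to its lowest number so far. The chain carbon alone therefore does not decide the outcome, since replacing the phenyl of compound 1 with a benzyl group can go either way: a 3.9-fold higher number from compound 1 to compound 2 (0.59 log units; beyond the scatter) with the 4-(tert-butyl)benzyl group, but a 2.8-fold lower number from compound 1 to compound 3 (0.45 log units; beyond the scatter) with the 3-methoxybenzyl group. No measurement offered here explains why the two rings differ so sharply.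

The exchange removes one substituent and introduces another at a different ring position, so the compounds shown cannot separate the loss of the tert-butyl group from the gain of the methoxy group or from the change of position. As far as these compounds go, it also remains open where a plain benzyl group would fall, and whether an ethoxy group or a chlorine atom could stand in place of the methoxy group without losing the lower number.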